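From 2,4-dichlorobenzyl to 3,4-dichlorobenzyl in compound 2

The source may hold more compounds than are shown below. What is called first, only, known or untested is meant among the compounds shown, and "the series" means these compounds.

Measured so far in a functional assay on MDA-MB-231 cells (Homo sapiens) for cytotoxicity, read by MTT assay, with a stated time of 72 h; on this read-out higher numbers stand for weaker inhibition and lower numbers for stronger inhibition:
- compound 1 `CN(C)Cc1ccc2nc(NC(=O)N/N=C/c3cn(Cc4ccc(Cl)cc4)c4ccccc34)sc2c1`: 880 nM
- compound 2 `CN(C)Cc1ccc2nc(NC(=O)N/N=C/c3cn(Cc4ccc(Cl)cc4Cl)c4ccccc34)sc2c1`: 1410 nM

Only these two compounds have been measured in this assay, and compound 2, at 1410 nM, stands within the scatter of compound 1. Compound 3 `CN(C)Cc1ccc2nc(NC(=O)N/N=C/c3cn(Cc4ccc(Cl)c(Cl)c4)c4ccccc34)sc2c1` carries 3,4-dichlorophenyl in place of 2,4-dichlorophenyl on a saturated chain carbon bound to an aromatic nitrogen. The two have the same atoms, joined differently. Among the compounds with values here, the one measured step that bears on this change is chloro in place of hydrogen on an aromatic carbon, a 1.6-fold higher number from compound 1 to compound 2 (0.20 log units; within the scatter). That step adds a chlorine and does not move one, so it is only indirect evidence. With that single step as a guide, no change beyond the scatter is expected. The expected step is a 1.3-fold lower number from compound 2 to compound 3 (0.11 log units; within the scatter). For compound 3 the estimated value is 1100 nM, with an expected range of 400 nM to 3000 nM.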

Compound 3, half-maximal inhibitory concentration: 1000 nM
For compound 3 the middle estimate is 1.1-fold (0.04 log units) above the measured one; measured number inside the range.
By their numbers in this assay, from the lowest: compounds 1, 3 and 2 (each within the scatter of the next).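

In this assay, the change from 2,4-dichlorobenzyl to 3,4-dichlorobenzyl gives a 1.4-fold lower number from compound 2 to compound 3 (0.15 log units; within the scatter), so rearranging the same atoms at this place, like adding a chlorine, makes no readable difference. The second chlorine in its new arrangement gives a 1.1-fold higher number from compound 1 to compound 3 (0.06 log units; within the scatter), which means that the three chlorinated groups shown at this place all lie within the scatter of one another. Nothing measured here gives a reason for these numbers.

Every group shown at this place is a chlorinated benzyl, so the effect of a methoxy group, a nitrile or an amine on that ring remains open, as does that of a longer chain to the aromatic nitrogen. Going by these compounds, how these compounds behave on any other cell line also remains open.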